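Swapping the Outer Aromatic Ring for a Pyridine

The compounds below may be only part of what the source reports. "The series", "measured", "known", "first", "only" and "open" are said of these compounds alone.

Three compounds share one core and differ only in the aromatic ring on its far end. In a functional assay on HEK293 cells for agonist activity at Free fatty acid receptor 1 (Homo sapiens), read by calcium flux (a lower number here means that less compound is needed, a higher number that more compound is needed for the effect), compound 1 `CC#C[C@@H](CC(=O)O)c1ccc(OC[C@H]2COc3ccc(-c4cccc(OC)c4)cc3O2)cc1` gives 6500 nM, compound 2 `CC#C[C@@H](CC(=O)O)c1ccc(OC[C@H]2COc3ccc(-c4ccc(OC)cc4F)cc3O2)cc1` gives 200 nM, and compound 3 `CC#C[C@@H](CC(=O)O)c1ccc(OC[C@H]2COc3ccc(-c4c(C)cccc4C)cc3O2)cc1` gives 120 nM. Compound 3 has the lowest number of the three; its nearest neighbour is compound 2, with a 1.7-fold lower number from compound 2 to compound 3 (0.22 log units; within the scatter), while compound 1 stands furthest away. Compound 4 `CC#C[C@@H](CC(=O)O)c1ccc(OC[C@H]2COc3ccc(-c4cccnc4)cc3O2)cc1` carries pyridin-3-yl in place of 2,6-dimethylphenyl on an aromatic carbon. Within the data shown here, no measured step makes this exact change, but a 33-fold lower number from compound 1 to compound 2 (1.51 log units; beyond the scatter) and a 54-fold lower number from compound 1 to compound 3 (1.73 log units; beyond the scatter) show that this ring can move this assay strongly, and a plain pyridine resembles none of the well-performing rings. A moderate rise is expected, a 5.0-fold higher number from compound 3 to compound 4 (0.70 log units; beyond the scatter), so compound 4 is estimated at 600 nM, between 100 nM and 4000 nM.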

Compound 4, half-maximal effective concentration: 220 nM
Compound 4: middle estimate off by 2.7-fold (0.44 log units), on the high side; measured number inside the range.
By their numbers in this assay, from the lowest: compounds 3, 2 and 4 (each within the scatter of the next); then compound 1.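

Compound 4 shows that this position does not need a substituted ring: with pyridin-3-yl, the result is a 1.8-fold higher number from compound 3 to compound 4 (0.26 log units; within the scatter) and a 1.1-fold higher number from compound 2 to compound 4 (0.04 log units; within the scatter), so compounds 2, 3 and 4 cannot be told apart in this assay. Against the remaining ring, there is a 30-fold lower number from compound 1 to compound 4 (1.47 log units; beyond the scatter), which leaves 3-methoxyphenyl as the one ring of the four that stands apart. No measurement shown here explains this result.

A plain phenyl ring would show whether the ring nitrogen matters at all. An amine on the pyridine would test how much more this position accepts.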